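Swapping an aryl ether for isopropyl in compound 2

A few compounds are considered here, and "the series" means these few. Any claim that something is new, unique, unknown or untested is made for them only; others in the source may bear on it.

Measured so far:
compound 1, `COc1ccccc1N1CCN(CCCNc2ccncc2C(=O)N(C)C)CC1`, 12.6 nM
compound 2, `CN(C)C(=O)c1cccnc1NCCCN1CCN(c2ccccc2OCC(F)(F)F)CC1`, 0.1 nM

In a functional assay for antagonist activity at Alpha-1A adrenergic receptor (Oryctolagus cuniculus) (on this read-out lower numbers stand for tighter binding and higher numbers for weaker binding), compound 2 gives the lowest of the two numbers; compound 1 sits well beyond the scatter with a far higher number. Compound 3, `CC(C)c1ccccc1N1CCN(CCCNc2ncccc2C(=O)N(C)C)CC1`, has not been measured. It differs from compound 2 by a single change: isopropyl in place of 2,2,2-trifluoroethoxy on an aromatic carbon. Among the compounds with values here, no directly comparable pair among the measured compounds shows the effect of such a swap, so the size of the step is uncertain. A moderate rise in this assay, beyond the scatter, is expected, a 10-fold higher number from compound 2 to compound 3 (1.00 log units; beyond the scatter). Compound 3 is estimated at 1 nM, between 0.1 nM and 10 nM.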

Compound 3, dissociation constant: 0.398 nM
The estimate for compound 3 lay 2.5-fold (0.40 log units) above the measured number, within the range that was stated.
By their numbers in this assay, from the lowest: compound 2; then compound 3; then compound 1.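

In this assay, replacing 2,2,2-trifluoroethoxy with isopropyl gives a 4.0-fold higher number from compound 2 to compound 3 (0.60 log units; beyond the scatter), a modest rise beyond the scatter. Even so, compound 3 gives 0.398 nM with no hydrogen-bond acceptor in this group, so a number this low does not require the ether oxygen or the fluorine atoms at this place, ortho to a large group. Nothing measured here explains the step.

Going by these compounds, how cyclopropyl, tert-butyl or a chlorine atom would read at this place remains open. So does whether the same swap would give a similar step on the core of compound 1.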